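Trifluoromethyl to 1,1-difluoroethyl: working notes on compound 4

This account rests on a few compounds, and the source may have more. Where it says the series, first, only, none or still open, it means among the compounds named here.

Measured in an in vitro ADME assay on microsomes from liver (Mus musculus) for metabolic stability; a higher number here means faster removal of the compound, a lower number slower removal:
- compound 1 (`COCc1nc2nc(C)cc(Nc3ccc(C(F)(F)F)cc3)n2n1`): 13.3 mL.min-1.g-1
- compound 2 (`Cc1cc(Nc2ccc(S(F)(F)(F)(F)F)cc2)n2nc(C(F)(F)F)nc2n1`): < 6 mL.min-1.g-1
- compound 3 (`CSc1nc2nc(C)cc(Nc3ccc(C(F)(F)F)cc3)n2n1`): 76.9 mL.min-1.g-1

Compound 2 reads < 6 mL.min-1.g-1, which is a limit of the assay and not a number. Compound 4 (`Cc1cc(Nc2ccc(S(F)(F)(F)(F)F)cc2)n2nc(C(C)(F)F)nc2n1`) has methyl in place of fluoro on a saturated chain carbon bound to an aromatic carbon and two fluorine atoms, which reads as trifluoromethyl to 1,1-difluoroethyl. For the measured compounds named here, the only measured step is a 5.8-fold higher number from compound 1 to compound 3 (0.76 log units; beyond the scatter) for a different exchange of groups, so it bears only loosely on this change. A rise smaller than that step is expected in this assay here. The estimated step is an at least 1.6-fold higher number from compound 2 to compound 4 (0.22 log units; that floor lies within the scatter) and remains uncertain given the limit at its start. For compound 4 the expected value is 10 mL.min-1.g-1 (estimated range 4 mL.min-1.g-1 to 30 mL.min-1.g-1).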

Compound 4, intrinsic clearance in microsomes: 8.1 mL.min-1.g-1
For compound 4 the middle estimate is 1.2-fold (0.09 log units) above the measured one; low and high end bracket the measured number.
By their numbers in this assay, from the lowest: compounds 4 and 1 (each within the scatter of the next); then compound 3. At a limit, below all of these: compound 2.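

In this assay, for the compounds shown here, trifluoromethyl to 1,1-difluoroethyl gives an at least 1.3-fold higher number from compound 2 to compound 4 (0.13 log units; that floor lies within the scatter), the only reading of a change on this saturated chain carbon bound to an aromatic carbon and two fluorine atoms. Compound 2 reads < 6 mL.min-1.g-1, which is a limit of the assay and not a number. The full size of the step cannot be read because it starts from a limit: the limit of < 6 mL.min-1.g-1 in this assay, at which 1 of the 4 values shown sits.

Still open, on these data alone, is how an amine or a longer chain in place of fluoro on this carbon would read in this assay, and whether exchanging a second fluoro for methyl would give a step beyond the scatter.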